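This account rests on a few compounds, and the source may have more. Where it says the series, first, only, none or still open, it means among the compounds named here.

Measured compounds:
Compound 1, `COc1ccc(/C=N/NC(=O)c2cc([N+](=O)[O-])cc([N+](=O)[O-])c2)cc1OC` — 2.83
Compound 2, `COc1ccc(/C=N/NC(=O)c2cccc([N+](=O)[O-])c2)cc1OC` — 2.87

Among the measured compounds shown here, in a physicochemical assay for lipophilicity (on this read-out lower numbers stand for lower lipophilicity and higher numbers for higher lipophilicity), compound 2 gives 2.87, the higher of the two numbers measured so far, while compound 1 gives 2.83; the difference a number 0.04 log units higher from compound 1 to compound 2 (within the scatter) is within the scatter, so the two compounds cannot be told apart on this read-out.

Compound 3, `COc1ccc(/C=N/NC(=O)c2cc([N+](=O)[O-])ccc2Cl)cc1OC`, has not yet been measured. It differs from compound 2 in one place: chloro in place of hydrogen on an aromatic carbon. For the measured compounds named here, no measured step covers this kind of change. Going by the values given here, the only step recorded, a number 0.04 log units higher from compound 1 to compound 2 (within the scatter), concerns a nitro group and lies within the scatter, so it says nothing directly about what a chloro group entering at this position will do. Any expectation for compound 3 therefore rests on the structural change alone and not on a measured precedent.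

On that basis a step of a number 0.63 log units higher from compound 2 to compound 3 (beyond the scatter) is expected in this assay, upward, beyond the scatter. Compound 3 is accordingly estimated at 3.5, with a range from 3.1 to 3.9.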

Compound 3, partition coefficient: 3.39
Compound 3: middle estimate off by 0.11 log units, on the high side; the measured number falls inside the stated range.
By their numbers in this assay, from the lowest: compounds 1 and 2 (each within the scatter of the next); then compound 3.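

In this assay, chloro in place of hydrogen on an aromatic carbon, ortho to a large group and para to a nitro group, comes with a number 0.52 log units higher from compound 2 to compound 3 (beyond the scatter), a modest step but the first in this series to lie beyond the scatter. Among the compounds shown here, the only earlier step, a number 0.04 log units higher from compound 1 to compound 2 (within the scatter), concerned a nitro group and stayed within the scatter, so this aromatic carbon is the first place where a single change clearly separates two compounds on this read-out. For the compounds shown here, nothing measured so far accounts for the size of this step.

The compounds shown leave open whether the step is particular to chloro or would be matched by another group on the same carbon, such as fluoro, methyl, an amine or a carboxylic acid. They also leave open whether chloro on a different carbon of this ring, or on the same carbon with the nitro group replaced by hydrogen, would give a step of similar size in this assay.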